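Replacing a Methylamino Group with a Fused Bicyclic Amine

This account rests on a few compounds, and the source may have more. Where it says the series, first, only, none or still open, it means among the compounds named here.

Compound 1 `COc1ccc(Nc2nc3cc(-c4ccc5c(ccn5C)c4)ccc3o2)cc1` carries a 4-methoxyphenylamino group on the shared core, and in an assay on HEK293 cells for inhibition of Fatty-acid amide hydrolase 1 (Homo sapiens), read by fluorescence (on this read-out lower numbers stand for stronger inhibition and higher numbers for weaker inhibition), compound 1 gives 280 nM. Compound 2 `CNc1nc2cc(-c3ccc4c(ccn4C)c3)ccc2o1` keeps the same core but has only a methylamino group at that spot. In this assay compound 2 reaches only the assay's limit of > 1000 nM, so for compound 2 a limit and no exact number is known. Shrinking the group on the ring nitrogen thus gave an at least 3.5-fold higher number from compound 1 to compound 2 (0.55 log units; beyond the scatter), and the true size of that step is only a lower bound because of the limit of > 1000 nM in this assay, at which 1 of the 2 values shown sits.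

Compound 3 `Cn1ccc2cc(-c3ccc4oc(N5Cc6cccnc6C5)nc4c3)ccc21` moves in the opposite direction from compound 2: a group of 9 heavy atoms (7 carbon, 2 nitrogen; one five-membered non-aromatic ring with 1 hetero atom, one six-membered aromatic ring with 1 hetero atom) in place of a group of 2 heavy atoms (1 carbon, 1 nitrogen; no ring), on an aromatic carbon. Among the compounds with values here, the single measured step shows that a larger substituent on that nitrogen went with a lower number, so a move back toward stronger inhibition is expected, although the new group is not the 4-methoxyphenyl of compound 1 and no measured step compares the two directly. For compound 3 in this assay the estimated value is 400 nM, with a likely range from 80 nM to 3000 nM. The expected step is therefore an at least 2.5-fold lower number from compound 2 to compound 3 (0.39 log units; beyond the scatter).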

Compound 3, half-maximal inhibitory concentration: 211 nM
Estimate against measurement, compound 3: 1.9-fold (0.28 log units) above; the range from low to high includes it.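

Putting the fused bicyclic amine in place of the methylamino group gives an at least 4.7-fold lower number from compound 2 to compound 3 (0.67 log units; beyond the scatter), and the true size of this step is known only as a lower bound because of an assay limit: the limit of > 1000 nM in this assay, at which 1 of the 3 values shown sits.

In this assay, the step of a 1.3-fold lower number from compound 1 to compound 3 (0.12 log units; within the scatter) lies within the scatter, so two quite different groups of 9 heavy atoms cannot be told apart at this spot, although one has a 4-methoxyphenyl ring and the other is a fused pair of rings. The group entering compound 3 also has 0 hydrogen-bond donors where the methylamino group has 1, so a value in this range at this position does not depend on a hydrogen-bond donor in the group, and among the three compounds shown, neither of the larger groups goes against the link between a larger group and a lower number.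

The compounds shown leave open whether size alone matters, as they include nothing of intermediate size, such as an ethylamino group or a plain pyrrolidine. They also leave open what the hetero atom in the six-membered aromatic ring contributes, which a matching benzene ring in that place could test.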